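Removing the Carboxyethyl Chain from a Rearranged Core

The compounds below may be only part of what the source reports. "The series", "measured", "known", "first", "only" and "open" are said of these compounds alone.

The series compares four compounds measured or planned in an assay on 32D cells for inhibition of interleukin-15 (Mus musculus), read by resazurin assay, with stated times of 30 min and 2.5 days, in the presence of a further agent that is not named here; on this read-out lower numbers stand for stronger inhibition and higher numbers for weaker inhibition. Compound 1 `Cn1nc(Cc2nnc(SCCCCCCCC(=O)Nc3ccc(Cl)cc3Cl)[nH]2)c2ccccc2c1=O` gives 1100 nM, while compound 2 `Cn1nc(Cc2nnc(SCCCCCCCC(=O)Nc3ccc(Cl)cc3Cl)n2CCC(=O)O)c2ccccc2c1=O` gives 23500 nM. The pair differs by hydrogen in place of 2-carboxyethyl on an aromatic nitrogen, and that step, a 21-fold lower number from compound 2 to compound 1 (1.33 log units; beyond the scatter), stands well beyond the scatter. Compound 3 `Cn1c(Cc2nn(CCC(=O)O)c(=O)c3ccccc23)nnc1SCCCCCCCC(=O)Nc1ccc(Cl)cc1Cl` shares its atoms with compound 2, but the difference between the two cores is not broken down here. For compound 3 this assay reports only a limit, > 30000 nM, consistent with the limit of > 30000 nM in this assay, at which 1 of the 3 values shown sits. Compound 4 `Cn1c(Cc2n[nH]c(=O)c3ccccc23)nnc1SCCCCCCCC(=O)Nc1ccc(Cl)cc1Cl` differs from compound 3 by hydrogen in place of 2-carboxyethyl on an aromatic nitrogen, the same kind of change as before, though here on an aromatic nitrogen of a six-membered aromatic ring with 2 nitrogen, part of a fused or bridged system of two rings, rather than a five-membered aromatic ring with 3 nitrogen. Resting on the step from compound 2 to compound 1, compound 4 is expected to show an at least 10-fold lower number from compound 3 to compound 4 (1.00 log units; beyond the scatter), giving an estimated 3000 nM, with a likely range from 700 nM to 20000 nM.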

Compound 4, half-maximal inhibitory concentration: > 30000 nM
Compound 4: no number, only a limit; the forecaster's own chance of this, stated with the estimate: 15%; middle value at least 10-fold (1.00 log units) from the limit.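

Within the data shown here, compound 3 and compound 4 both give only a limit in this assay, so no step between them can be read: the limit of > 30000 nM in this assay, at which 2 of the 4 values shown sit. As far as these compounds go, whether hydrogen in place of 2-carboxyethyl on this aromatic nitrogen changes the number at all remains open.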